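From an Ester Side Chain to a Fluorinated Ring

The source may report more compounds than this note shows. Statements on the series, on what has been measured and on what is new or still open speak of the compounds shown alone.

In a functional assay on a cell-free system (plasma, Oryctolagus cuniculus) for inhibition, with stated times of 5 min, 1 min and 6 min (a lower number here means a stronger inhibitor, a higher number a weaker inhibitor), compound 1 `CCOC(=O)c1c(C)nc(-c2cccc(C#N)c2)n1OC` gives 9130 nM, compound 2 `CCOC(=O)c1c(C)nc(-c2cccc(C#N)c2)n1OC(C)C` gives 6740 nM and compound 3 `CCOC(=O)COn1c(-c2cccc(C#N)c2)nc(C)c1C(=O)OCC` gives 6800 nM, so compound 3 stands level with the other two within the scatter. Compound 4 `CCOC(=O)c1c(C)nc(-c2cccc(C#N)c2)n1OCc1ccccc1F` has 2-fluorophenyl in place of ethoxycarbonyl on a saturated chain carbon bound to an oxygen on an aromatic ring. Three measured changes at this oxygen bear on it: a 1.4-fold lower number from compound 1 to compound 2 (0.13 log units; within the scatter), a 1.3-fold lower number from compound 1 to compound 3 (0.13 log units; within the scatter) and a 1.0-fold higher number from compound 2 to compound 3 (0.00 log units; within the scatter). None of them introduces a ring, so they guide this change only loosely, and no shift beyond the scatter is expected. The estimated step is a 1.4-fold lower number from compound 3 to compound 4 (0.13 log units; within the scatter). The expected value for compound 4 is 5000 nM, with an estimated range from 1500 nM to 15000 nM.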

Compound 4, half-maximal inhibitory concentration: 8990 nM
Beside the measured number, compound 4's estimate is 1.8-fold (0.25 log units) below it; measured number inside the range.
By their numbers in this assay, from the lowest: compounds 2, 3, 4 and 1 (each within the scatter of the next).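

Even a ring on the chain at this oxygen leaves the number in this assay where it was: 2-fluorophenyl in place of ethoxycarbonyl gives a 1.3-fold higher number from compound 3 to compound 4 (0.12 log units; within the scatter) and 2-fluorobenzyl in place of isopropyl gives a 1.3-fold higher number from compound 2 to compound 4 (0.13 log units; within the scatter). Measured against the methyl group, the ring gives a 1.0-fold lower number from compound 1 to compound 4 (0.01 log units; within the scatter) so all four groups on this oxygen read alike here. Nothing available explains this flat result.

From the compounds shown here alone, whether plain benzyl reads the same as 2-fluorobenzyl remains open. So does the effect of an amine or a carboxylic acid on this oxygen.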